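Fluoro to Nitro: Expecting Little Change in Potency

The compounds below may be only part of what the source reports. "The series", "measured", "known", "first", "only" and "open" are said of these compounds alone.

Compound 1 `O=C(CCCCCc1ccccc1)c1nc2ccc(F)cc2o1` was tested in an assay on HEK-293T cells for inhibition of diacylglycerol lipase-alpha (Homo sapiens), read by colorimetric assay (a higher number here means a weaker inhibitor, a lower number a stronger inhibitor), where compound 1 gives 708 nM. Among the measured compounds shown here, only one other compound has been measured so far: compound 2 `O=C(CCCCCc1ccccc1)c1nc2cc([N+](=O)[O-])ccc2o1`, which carries a nitro group in a different position on the same core and which in this assay gives 891 nM. Compound 1 has the lower of the two numbers, but the gap to compound 2 is small enough to lie within the usual scatter of repeated measurements, so the two compounds cannot be ranked against each other.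

Compound 3 `O=C(CCCCCc1ccccc1)c1nc2ccc([N+](=O)[O-])cc2o1` is the next compound to be measured. It differs from compound 1 in one place: nitro in place of fluoro on an aromatic carbon. In words, a nitro group takes the place of the fluoro on the same aromatic carbon of the core. For the measured compounds named here, no directly comparable step between measured compounds exists for this change.

Because compound 2 with a nitro elsewhere on the core gives 891 nM, a number close to that of compound 1, the step from compound 1 to compound 3 is expected to be small, a 1.2-fold higher number from compound 1 to compound 3 (0.08 log units; within the scatter), and not beyond the scatter in either direction. Compound 3 is therefore estimated to give 850 nM in this assay, with a likely range from 350 nM to 2100 nM.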

Compound 3, half-maximal inhibitory concentration: 87.1 nM
The estimate for compound 3 lay 9.8-fold (0.99 log units) above the measured number, outside the stated range (below it).
By their numbers in this assay, from the lowest: compound 3; then compounds 1 and 2 (each within the scatter of the next).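

Nitro in place of fluoro on this aromatic carbon gives an 8.1-fold lower number from compound 1 to compound 3 (0.91 log units; beyond the scatter) in this assay, a step well clear of the scatter, so what this carbon carries clearly affects the result. Until now, the measured compounds could not be ranked against each other; this single exchange, with the rest of the molecule unchanged, gives a clearly stronger inhibitor and the first real difference in the series. Among the compounds shown here, nothing measured so far bears on why nitro and fluoro differ so much here.

As far as these compounds go, only these two groups can be compared on this carbon, so a single step cannot show a trend, and it remains open whether the gain belongs to nitro alone or would also appear with a nitrile, a trifluoromethyl, an amine or a carboxylic acid in the same place. From the compounds shown here alone, it also remains open whether the same exchange would give a step of similar size on another aromatic carbon of the core, or with a shorter or longer chain attached to the carbonyl.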